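The source may hold more compounds than are shown below. What is called first, only, known or untested is meant among the compounds shown, and "the series" means these compounds.

Among the measured compounds shown here, compound 2, `CC(C(=O)NCc1ccc(Cl)cc1)N1C(=O)CCC1=O`, is one of two compounds measured so far. In a functional assay on the whole organism (strain Albino Swiss CD1) with Mus musculus as the target, in the maximal electroshock model (on this read-out higher numbers stand for an effect only at larger amounts of compound and lower numbers for an effect already at smaller amounts), compound 2 gives 91.8 mg/kg. Compound 1, `CC(C(=O)NCc1ccccc1Cl)N1C(=O)CCC1=O`, gives 74.5 mg/kg in this assay, and the two values lie within the scatter of each other, so neither can be set apart from the other. Compound 3, `CCC(C(=O)NCc1ccc(Cl)cc1)N1C(=O)CCC1=O`, has not yet been measured. It differs from compound 2 in a single place: methyl in place of hydrogen on a saturated chain carbon, two bonds along the chain from an amide-type nitrogen in a ring and a carbonyl carbon. For the measured compounds named here, no pair of measured compounds shows what this kind of change does in this assay, so there is no measured step to set a direction or size against. The step of a 1.1-fold lower number from compound 2 to compound 3 (0.03 log units; within the scatter) is expected to be small, without a clear direction, and not beyond the scatter. On that basis compound 3 is estimated at 85 mg/kg in this assay, with a range from 40 mg/kg to 180 mg/kg.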

Compound 3, dose for half-maximal effect: 95.4 mg/kg
Compound 3: the middle estimate sits 1.1-fold (0.05 log units) below what was measured; measured number inside the range.
By their numbers in this assay, from the lowest: compounds 1, 2 and 3 (each within the scatter of the next).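

Methyl in place of hydrogen on the saturated chain carbon, two bonds along the chain from an amide-type nitrogen in a ring and a carbonyl carbon, gives a 1.0-fold higher number from compound 2 to compound 3 (0.02 log units; within the scatter) in this assay. Among the compounds shown here, this is the first measured step at this position, and it shows that going from methyl to ethyl here leaves the number within the scatter, so one added carbon at this place does not set compound 3 apart from compound 2. No measurement shown here offers an explanation for this result.

Going by these compounds, whether a longer chain such as propyl, or a phenyl ring, on this carbon would also leave the number in place remains open. A single step also cannot tell whether the same change would behave alike on compound 1.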